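Swapping an aromatic amide substituent for tert-butyl

The compounds below may be only part of what the source reports. "The series", "measured", "known", "first", "only" and "open" are said of these compounds alone.

The compounds here share one core and differ in the group on the amide nitrogen or on the saturated ring carbon. Compound 1 `C=CC1=C(C(=O)NCc2ccc(Cl)cc2)C(c2ccc(F)cc2)OC1` carries a 4-chlorobenzyl group on that nitrogen; in a functional assay on QGY7701 cells (Homo sapiens) for cytotoxicity, read by MTT assay, with a stated time of 24 h (a higher number here means a weaker inhibitor, a lower number a stronger inhibitor), compound 1 gives 36900 nM. Compound 2 `C=CC1=C(C(=O)Nc2ccccc2OC)C(c2ccc(F)cc2)OC1` carries 2-methoxyphenyl instead, and in this assay compound 2 gives 52800 nM. That change is a 1.4-fold higher number from compound 1 to compound 2 (0.16 log units; within the scatter). Compound 3 `C=CC1=C(C(=O)Nc2ccccc2OC)C(c2ccc(Cl)c(Cl)c2)OC1` keeps the same amide but has 3,4-dichlorophenyl on the saturated ring carbon; for compound 3 this assay reports only a limit, > 100000 nM, as described by the limit of > 100000 nM in this assay, at which 1 of the 3 values shown sits. The step is therefore an at least 1.8-fold higher number from compound 2 to compound 3 (0.27 log units; that floor lies within the scatter).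

Among the two plain numbers, compound 2 gives the higher one, with compound 1 nearest to it within the scatter. Compound 4 `C=CC1=C(C(=O)NC(C)(C)C)C(c2ccc(F)cc2)OC1` differs from compound 2 in one place: tert-butyl in place of 2-methoxyphenyl on an amide-type nitrogen. For the measured compounds named here, the only step that touches the amide nitrogen is the one from compound 1 to compound 2, and it stayed within the scatter; nothing measured here compares an aromatic group with a small branched alkyl such as tert-butyl. The expectation is therefore a step of a 1.1-fold higher number from compound 2 to compound 4 (0.06 log units; within the scatter), not clearly beyond the scatter. For compound 4 the estimate in this assay is 60000 nM, expected between 25000 nM and 150000 nM.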

Compound 4, half-maximal inhibitory concentration: > 100000 nM
Compound 4 was reported as a limit (the forecaster's own chance of this, stated with the estimate: 25%); at least 1.6-fold (0.22 log units) between middle value and limit.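

In this assay, for the compounds shown here, tert-butyl in place of 4-chlorobenzyl on the amide-type nitrogen gives an at least 2.7-fold higher number from compound 1 to compound 4 (0.43 log units; beyond the scatter), the first change at this position to go beyond the scatter. Compound 4 is reported only as a limit, so tert-butyl in place of 2-methoxyphenyl gives an at least 1.8-fold higher number from compound 2 to compound 4 (0.27 log units; that floor lies within the scatter), and the true size of that step could lie within or beyond the scatter. Tert-butyl, the only group without a ring on this nitrogen among these compounds, thus joins a change on the saturated ring carbon at the top of the reported range: the limit of > 100000 nM in this assay, at which 2 of the 4 values shown sit.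

The compounds shown leave open whether the absence of a ring or something particular to tert-butyl accounts for the step from compound 1, and a cyclohexyl group or a straight butyl chain on the same nitrogen would help to separate the two. They also leave open how far compound 4 lies past its limit, and whether a carboxylic acid or an amine on the amide substituent would give a lower number than the 4-chlorobenzyl group.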